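Nitro in Place of Methoxy: What Compound 3 Might Give

A few compounds are considered here, and "the series" means these few. Any claim that something is new, unique, unknown or untested is made for them only; others in the source may bear on it.

compound 1 `Cc1ccc2c(c1)/C(=N/NC(=S)N1CCN(c3ccccc3)CC1)C(=O)N2`: 9480 nM
compound 2 `COc1ccc(N2CCN(C(=S)N/N=C3\C(=O)Nc4ccc(Cl)cc43)CC2)cc1`: 7740 nM

In a functional assay on HCT-116 cells (Homo sapiens) for inhibition, read by MTT assay, with a stated time of 72 h (a higher number here means a weaker inhibitor, a lower number a stronger inhibitor), compound 2 holds the lowest of the two numbers shown, yet compound 1, the nearest, stands within the scatter of it, so the two cannot be told apart. Compound 3 `O=C1Nc2ccc(Cl)cc2/C1=N/NC(=S)N1CCN(c2ccc([N+](=O)[O-])cc2)CC1` differs from compound 2 in one place: nitro in place of methoxy on an aromatic carbon. Going by the values given here, no measured pair shows this change, so the expected step is none beyond the scatter, a 1.4-fold lower number from compound 2 to compound 3 (0.15 log units; within the scatter). Compound 3 is accordingly estimated at 5500 nM in this assay, with a range from 1800 nM to 17000 nM.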

Compound 3, half-maximal inhibitory concentration: 12000 nM
Compound 3: the middle estimate sits 2.2-fold (0.34 log units) below what was measured, within the range that was stated.
By their numbers in this assay, from the lowest: compounds 2, 1 and 3 (each within the scatter of the next).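

In this assay, going by these compounds alone, the change from 4-methoxyphenyl to 4-nitrophenyl gives a 1.6-fold higher number from compound 2 to compound 3 (0.19 log units; within the scatter) and so stays within the scatter, which is the first comparison here in which only one place differs. At this place, para to a large group, these two groups cannot be told apart. Nothing measured here bears on this result. As far as these compounds go, whether an amine or a carboxylic acid at this place would give a step beyond the scatter stays open. So does whether the same change would read alike on another core.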